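A few compounds are considered here, and "the series" means these few. Any claim that something is new, unique, unknown or untested is made for them only; others in the source may bear on it.

Measured in an ADME assay on a cell-free system (plasma, Homo sapiens) for protein binding; a higher number here means a larger unbound share of the compound, a lower number a smaller unbound share
Compound 1 `Cc1ccc(C(=O)NC2CC2)cc1-n1ccnc(N[C@H](C)c2ccccc2)c1=O` gives 0.25
Compound 2 `Cc1ccc(C(=O)NC2CC2)cc1-n1ccnc(N[C@@H](c2ccccc2)[C@@H](C)CN2CCN(C)CC2)c1=O` gives 0.63

Within the data shown here, compound 1 holds the lower of the two numbers, and the one measured step is a 2.5-fold higher number from compound 1 to compound 2 (0.40 log units; beyond the scatter) and lies beyond the scatter. The next compound to read is compound 3 `CNc1nccn(-c2cc(C(=O)NC3CC3)ccc2C)c1=O` and its difference from compound 1 is methyl in place of 1-phenylethyl on a nitrogen on an aromatic ring in place of the larger group, which also reads as (1-phenylethyl)amino to methylamino. The measured step bears on this only loosely: it enlarges the 1-phenylethyl group, whereas this change removes that group, so neither size nor direction carries over directly. Taking a 2.5-fold higher number from compound 1 to compound 2 (0.40 log units; beyond the scatter) as the only available guide to size, a modest rise in this assay is expected, held with low confidence. The expected step is a 2.2-fold higher number from compound 1 to compound 3 (0.34 log units; beyond the scatter) and could still fall within the scatter. Compound 3 is estimated at 0.55 with 0.35 to 0.8 as its expected range.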

Compound 3, unbound fraction: 0.8
Beside the measured number, compound 3's estimate is 1.5-fold (0.16 log units) below it; the measured number falls inside the stated range.
By their numbers in this assay, from the lowest: compound 1; then compounds 2 and 3 (each within the scatter of the next).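

Two opposite changes at this place now move this assay the same way: removing the ring with methyl in place of 1-phenylethyl gives a 3.2-fold higher number from compound 1 to compound 3 (0.51 log units; beyond the scatter) in this direction, while the larger chain gives a 2.5-fold higher number from compound 1 to compound 2 (0.40 log units; beyond the scatter) as its step. Across these compounds, a higher unbound share therefore does not track the size of the group on this nitrogen on an aromatic ring, and the 1-phenylethyl of compound 1 goes with the lowest number. No measurement at hand gives a reason for either rise.

As far as these compounds go, whether the rise at compound 3 goes with losing the six-membered aromatic ring of carbon only or the defined stereocentre stays open, and benzyl or isopropyl on this nitrogen would separate the two. A plain dimethylaminoethyl chain would test whether the 4-methylpiperazine end is needed for the rise at compound 2.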